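Adding a Methyl to Compound 1

The source may hold more compounds than are shown below. What is called first, only, known or untested is meant among the compounds shown, and "the series" means these compounds.

Compound 1 `CNc1cc(C)c(C(N)=O)cn1` was tested in an assay on isolated protein for inhibition of Nicotinamide N-methyltransferase (Homo sapiens), read by luminescence, with a stated time of 20 min (on this read-out higher numbers stand for weaker inhibition and lower numbers for stronger inhibition), where compound 1 gives 282 nM. Of the two numbers shown it is the lowest; its nearest neighbour is compound 2 `CNc1cc(Cl)c(C(N)=O)cn1`, which in this assay gives 639 nM, the step being a 2.3-fold higher number from compound 1 to compound 2 (0.36 log units; beyond the scatter). Compound 3 `CNc1cc(C)c(C(N)=S)cn1` in this assay gives > 10000 nM, which is a limit of the assay and not a number (the limit of > 10000 nM in this assay, at which 1 of the 3 values shown sits). The step of an at least 35-fold higher number from compound 1 to compound 3 (1.54 log units; beyond the scatter) is thus known only as a lower bound.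

Compound 4 `CNc1ncc(C(N)=O)c(C)c1C` differs from compound 1 in that (methyl in place of hydrogen on an aromatic carbon). Neither measured step matches this change closely. The step of a 2.3-fold higher number from compound 1 to compound 2 (0.36 log units; beyond the scatter) exchanges methyl for chloro rather than adding a group, and the step of an at least 35-fold higher number from compound 1 to compound 3 (1.54 log units; beyond the scatter) alters the carbamoyl group, which compound 4 keeps intact. Within the data shown here, the only substituent change left in place on the ring, from compound 1 to compound 2, was modest, so an added methyl is expected to move the number in this assay by a small amount at most, more likely upward than downward, with no strong reason to expect a step beyond the scatter. Compound 4 is therefore estimated at 400 nM, with a range from 120 nM to 1400 nM. That estimate corresponds to an expected step of a 1.4-fold higher number from compound 1 to compound 4 (0.15 log units; within the scatter).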

Compound 4, half-maximal inhibitory concentration: > 10000 nM
Compound 4: no number, only a limit; the forecaster's own chance of this, stated with the estimate: 5%; middle value at least 25-fold (1.39 log units) from the limit.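

In this assay compound 4 gives > 10000 nM, which is a limit of the assay and not a number. Among these compounds, the step, an at least 35-fold higher number from compound 1 to compound 4 (1.54 log units; beyond the scatter), is therefore known only as a lower bound, and it shows that the aromatic carbon ortho to both the methyl group and the methylamino group is far less forgiving than the earlier compounds suggested, since the only ring change among them was the modest 2.3-fold higher number from compound 1 to compound 2 (0.36 log units; beyond the scatter). The one large step seen before altered the carbamoyl group, whereas here that group stays intact and a single methyl in place of hydrogen on the ring is enough to reach the same limit as compound 3: the limit of > 10000 nM in this assay, at which 2 of the 4 values shown sit.

The compounds shown leave open whether fluorine, a hydroxyl or an amine on this carbon would keep the number close to that of compound 1, or whether any group in place of hydrogen there has the same outcome. They also do not tell how far beyond the limit compound 4 lies, or why this one added methyl has so large an effect.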